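This account rests on a few compounds, and the source may have more. Where it says the series, first, only, none or still open, it means among the compounds named here.

Two compounds share one core and differ from each other at two places. Compound 1 (`CCNC(=O)Nc1ccc(S(=O)(=O)Oc2ccccc2I)cc1`) in a functional assay on M21 cells (Homo sapiens) for antiproliferative activity, read by sulforhodamine B assay, with a stated time of 48 h (a lower number here means a stronger inhibitor, a higher number a weaker inhibitor), gives 5600 nM. Compound 2 (`CCCCCNC(=O)Nc1ccc(S(=O)(=O)Oc2ccccc2C(C)C)cc1`) in this assay gives 4600 nM. These two numbers lie within the usual scatter of each other, so the measurements do not separate compound 2 from compound 1; compound 2 simply holds one of two values that sit side by side. Compound 3 (`CCCCCNC(=O)Nc1ccc(S(=O)(=O)Oc2ccccc2I)cc1`) has not yet been measured. It differs from compound 2 in one place: iodo in place of isopropyl on an aromatic carbon. No step between measured compounds changes only this one place, so the size of the step is not shown by the data. Compound 3 carries the same iodo group as compound 1, and both measured values sit close together. For compound 3 in this assay the expected value is 5000 nM, with a range from 2500 nM to 10000 nM. The expected step of a 1.1-fold higher number from compound 2 to compound 3 (0.04 log units; within the scatter) is none beyond the scatter.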

Compound 3, half-maximal inhibitory concentration: 5900 nM
Compound 3: the middle estimate sits 1.2-fold (0.07 log units) below what was measured; the measured number falls inside the stated range.
By their numbers in this assay, from the lowest: compounds 2, 1 and 3 (each within the scatter of the next).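

In this assay iodo in place of isopropyl, on an aromatic carbon ortho to a large group, gives a 1.3-fold higher number from compound 2 to compound 3 (0.11 log units; within the scatter) and so does not tell these two groups apart at this place. The chain can now be read alone as well: propyl in place of hydrogen on a saturated chain carbon, two bonds along the chain from an amide-type nitrogen, gives a 1.1-fold higher number from compound 1 to compound 3 (0.02 log units; within the scatter) and also stays inside the scatter. Each of the two places that separated compound 1 from compound 2 has thus been read on its own, and neither change separates the compounds.

No further measurement bears on these results. Still open, as far as these compounds go, is whether an amine or a carboxylic acid in place of the iodo group, or a longer chain, would give a step beyond the scatter.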